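Swapping a Halogenated Phenyl Ring on a Thiazolidinone Core

The source may hold more compounds than are shown below. What is called first, only, known or untested is meant among the compounds shown, and "the series" means these compounds.

Measured compounds:
compound 1, `COc1ccccc1C1SCC(=O)N1CCN1CCCCC1`, 100%
compound 2, `O=C1CSC(c2ccc(F)cc2)N1CCN1CCCCC1`, 87%

Of the compounds shown here, two sharing one core have been tested in an ADME assay on Vero cells (Chlorocebus sabaeus) for cytotoxicity, read by neutral red uptake, tested at 98 ug/mL; a higher number here means a weaker effect of the compound at the concentration tested, a lower number a stronger effect. Compound 1 gives 100%, and compound 2 gives 87%. Among these two numbers, compound 2 stands lowest; the only neighbour, compound 1, lies higher by a gap beyond the usual scatter.

Compound 3, `O=C1CSC(c2ccccc2Cl)N1CCN1CCCCC1`, has not yet been tested in this assay. It differs from compound 2 in a single place: 2-chlorophenyl in place of 4-fluorophenyl on a saturated ring carbon. Going by the values given here, no measured pair that differs in just one place is available, so the size of this kind of step is unknown here.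

For compound 3 a step of a number 3 percentage points higher from compound 2 to compound 3 (within the scatter) is expected, small and likely within the scatter, in either direction. Compound 3 is therefore estimated to give about 90% in this assay, within a range of 75% to 100%.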

Compound 3, a percentage reported as activity, at one concentration (the size of the read-out at that concentration, not a potency): 94%
Compound 3: middle estimate off by 4 percentage points, on the low side; low and high end bracket the measured number.
By their numbers in this assay, from the lowest: compounds 2, 3 and 1 (each within the scatter of the next, the first and the last beyond it).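

In this assay, replacing 4-fluorophenyl with 2-chlorophenyl on the saturated ring carbon gives a number 7 percentage points higher from compound 2 to compound 3 (within the scatter) and so does not clearly shift the read-out, even though both the halogen and the ring place it occupies change at once. Chloro in place of methoxy on an aromatic carbon gives a number 6 percentage points lower from compound 1 to compound 3 (within the scatter) and is likewise too small to separate from repeat-to-repeat variation, so these two one-place changes show no measurable effect here. Nothing measured here explains why these steps are so small.

On these data alone, whether a larger change at this ring carbon would produce a clear step remains open, for example a phenyl ring carrying an amine or a carboxylic acid, or a longer chain in place of the ring. The separate contributions of the halogen and its place on the ring also remain unresolved, since compound 2 and compound 3 differ in both.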